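Cyclopropylsulfonyl to (4-chlorophenyl)carbamoyl: notes on a small series

The source may report more compounds than this note shows. Statements on the series, on what has been measured and on what is new or still open speak of the compounds shown alone.

Of the compounds shown here, three built on a shared core have been measured so far in a functional assay on MDA-MB-436 cells (Homo sapiens) for antiproliferative activity, read by MTT assay, with a stated time of 48 h (a higher number here means a weaker inhibitor, a lower number a stronger inhibitor), as the read-out. Compound 1 (`C=CS(=O)(=O)N1CCN(c2ncnc3sc(-c4ccc(OC)cc4)cc23)CC1`) gives the highest number of the three (28400 nM) and compound 2 (`C=CS(=O)(=O)N1CCN(c2nc(OC[C@H]3CCCN3C)nc3sc(-c4ccc(OC)nc4)cc23)CC1`) gives the lowest (4980 nM). Compound 3 (`CN1CCN(c2ccc(-c3cc4c(N5CCN(S(=O)(=O)C6CC6)CC5)ncnc4s3)cc2)CC1`) stands second highest (10600 nM), beyond the scatter from both of the others, with compound 2 its nearest neighbour and compound 1 its furthest.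

Compound 4 (`CN1CCN(c2ccc(-c3cc4c(N5CCN(C(=O)Nc6ccc(Cl)cc6)CC5)ncnc4s3)cc2)CC1`) keeps the rest of compound 3 but carries (4-chlorophenyl)carbamoyl in place of cyclopropylsulfonyl on an amine nitrogen in a ring. Within the data shown here, no two measured compounds differ in one place only, so the series offers no direct measure of this change. Among the measured compounds shown here, the only guide is the span of the measured values, which runs from compound 2 (4980 nM) to compound 1 (28400 nM). A modest move to a lower number is expected (a 2.1-fold lower number from compound 3 to compound 4 (0.33 log units; beyond the scatter)), although a result with no change beyond the scatter remains quite possible. In this assay the estimated value for compound 4 is 5000 nM (expected range 1200 nM to 20000 nM).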

Compound 4, half-maximal inhibitory concentration: 9270 nM
Estimate against measurement, compound 4: 1.9-fold (0.27 log units) below; the range from low to high includes it.
By their numbers in this assay, from the lowest: compounds 2, 4 and 3 (each within the scatter of the next, the first and the last beyond it); then compound 1.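

Among these compounds, the one-place step in this assay is a 1.1-fold lower number from compound 3 to compound 4 (0.06 log units; within the scatter), the first direct reading at this position, and it shows no separation between the two groups. On an amine nitrogen in a ring, the read-out therefore does not distinguish cyclopropylsulfonyl from (4-chlorophenyl)carbamoyl, even though the exchange swaps a three-membered non-aromatic ring for a six-membered aromatic ring, adds heavy atoms and brings in a hydrogen-bond donor. No supporting evidence bears on this result, so the match between the two compounds stays an observation without an explanation.

From the compounds shown here alone, with only these two groups compared at this nitrogen, it remains open whether the read-out responds to this position at all or whether these two groups simply happen to coincide. A plain acetyl, an unsubstituted phenylcarbamoyl or a carbamoyl carrying a carboxylic acid on its aromatic ring would test this, and the phenylcarbamoyl would also separate the contribution of the chlorine from that of the rest of the group.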